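Working notes: from compound 3 to compound 4

The source may hold more compounds than are shown below. What is called first, only, known or untested is meant among the compounds shown, and "the series" means these compounds.

Values in a functional assay on Jurkat cells (Homo sapiens); on this read-out lower numbers stand for stronger inhibition and higher numbers for weaker inhibition:
- compound 1 `C[C@H](NC(=O)C(=O)NCCC1CCCC1)C(=O)N[C@@H](CC(=O)O)C(=O)COc1c(F)c(F)cc(F)c1F`: 11 nM
- compound 2 `C[C@H](NC(=O)C(=O)NCc1ccccc1F)C(=O)N[C@@H](CC(=O)O)C(=O)COc1c(F)c(F)cc(F)c1F`: 207 nM
- compound 3 `Cc1ccc(CNC(=O)C(=O)N[C@@H](C)C(=O)N[C@@H](CC(=O)O)C(=O)COc2c(F)c(F)cc(F)c2F)c(C)c1`: > 10000 nM (a limit, not a number)

Compound 3 stands at the limit of > 10000 nM in this assay, at which 1 of the 3 values shown sits. The next change leads to compound 4 `C[C@H](NC(=O)C(=O)NCc1cccc(Cl)c1Cl)C(=O)N[C@@H](CC(=O)O)C(=O)COc1c(F)c(F)cc(F)c1F`: 2,3-dichlorophenyl in place of 2,4-dimethylphenyl on a saturated chain carbon bound to an amide-type nitrogen. In words, this is 2,3-dichlorophenyl in place of 2,4-dimethylphenyl on a saturated chain carbon bound to an amide-type nitrogen.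

Within the data shown here, the closest precedent is the large aryl-for-aryl step an at least 48-fold higher number from compound 2 to compound 3 (1.68 log units; beyond the scatter). The steps of a 19-fold higher number from compound 1 to compound 2 (1.27 log units; beyond the scatter) and an at least 900-fold higher number from compound 1 to compound 3 (2.95 log units; beyond the scatter) are also large, so the group at this place has moved this assay strongly in all three compounds. On these data alone, with so few compounds, the 2,3-dichlorophenyl group remains untested here. Among the measured compounds shown here, a large step towards a lower number is nevertheless expected, resting on compound 2 at 207 nM, the only aryl compound with a measured number. The estimated step is an at least 20-fold lower number from compound 3 to compound 4 (1.30 log units; beyond the scatter). For compound 4 the estimate is 500 nM, with an expected range of 50 nM to 8000 nM.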

Compound 4, half-maximal inhibitory concentration: 76 nM
Estimate against measurement, compound 4: 6.6-fold (0.82 log units) above; low and high end bracket the measured number.
By their numbers in this assay, from the lowest: compound 1; then compound 4; then compound 2. At a limit, above all of these: compound 3.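

In this assay, an aryl group at this position does not by itself decide the outcome, since swapping 2,4-dimethylphenyl for 2,3-dichlorophenyl gives an at least 130-fold lower number from compound 3 to compound 4 (2.11 log units; beyond the scatter). Compound 3 stands at a limit, not a number, so that step has only a bound for its size: the limit of > 10000 nM in this assay, at which 1 of the 4 values shown sits. The 2,3-dichlorophenyl group also improves on 2-fluorophenyl, with a 2.7-fold lower number from compound 2 to compound 4 (0.44 log units; beyond the scatter), but falls short of cyclopentylmethyl, with a 6.9-fold higher number from compound 1 to compound 4 (0.84 log units; beyond the scatter).

Open, on these data alone, is whether the result follows the chlorine atoms or their placement, since 2,3-dichlorophenyl and 2,4-dimethylphenyl differ in both, and 2,4-dichlorophenyl or 2,3-dimethylphenyl would separate the two. Also open, as far as these compounds go, is whether a longer chain, such as 2-(2,3-dichlorophenyl)ethyl in place of 2,3-dichlorobenzyl, would bring the aryl series closer to compound 1.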